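The compounds below may be only part of what the source reports. "The series", "measured", "known", "first", "only" and "open" are said of these compounds alone.

Measured so far:
compound 1, `N#Cc1c(Nc2ccc(O)cc2)nc(SCC(=O)Nn2c(COc3ccc(Cl)cc3Cl)nc3ccccc3c2=O)nc1-c1ccc(Cl)cc1`, gives 71.2% in a functional assay on the whole organism (strain albino) for inhibition, with Rattus norvegicus as the target, read by paw edema, with stated times of 1 h and 0.5 h, at a dose of 100 mg/kg by the oral route; on this read-out lower numbers stand for less inhibition and higher numbers for more inhibition at the one dose given (going by the name of the read-out)
compound 2, `N#Cc1c(Nc2ccc(Cl)cc2)nc(SCC(=O)Nn2c(COc3ccc(Cl)cc3Cl)nc3ccccc3c2=O)nc1-c1ccc(O)cc1`, gives 65.4%

Compound 2 stands lowest of the two numbers, but compound 1 sits within the usual scatter of it, so no order between the two can be read. Compound 3, `N#Cc1c(Nc2ccc(O)cc2)nc(SCC(=O)Nn2c(COc3ccc(Cl)cc3Cl)nc3ccccc3c2=O)nc1-c1ccc(O)cc1`, is not yet measured. It differs from compound 2 in one place: hydroxy in place of chloro on an aromatic carbon. Among the compounds with values here, with no measured step of this kind to lean on, the expected step in this assay, a number 2.6 percentage points higher from compound 2 to compound 3 (within the scatter), is estimated to stay within the scatter, in no clear direction. Compound 3 is therefore expected to give about 68%, between 55% and 80%.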

Compound 3, a percentage reported as inhibition, in the whole organism at one dose (the size of the read-out at that dose, not a potency): 80.8%
For compound 3 the middle estimate is 12.8 percentage points below the measured one; the measured number lies above the stated range.
By their numbers in this assay, from the lowest: compounds 2, 1 and 3 (each within the scatter of the next, the first and the last beyond it).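

In this assay the swap of chloro for hydroxy, made on the (4-chlorophenyl)amino group, gives a number 15.4 percentage points higher from compound 2 to compound 3 (beyond the scatter) and so shows a real gain at this position. The same swap on the other 4-chlorophenyl group gives a number 9.6 percentage points higher from compound 1 to compound 3 (within the scatter) and cannot be read as a gain, so only the first position shows a clear effect. Nothing measured here explains that gain.

From the compounds shown here alone, whether a methoxy group or an amine in the same place would match hydroxy remains open. So does how these compounds behave at any other dose.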